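Swapping one ring atom in the amide-side substituent

This account rests on a few compounds, and the source may have more. Where it says the series, first, only, none or still open, it means among the compounds named here.

Measured so far:
compound 1 `O=C(CCSc1ccc2c(/C=C/c3ccccn3)n[nH]c2c1)Nc1ccc(F)c(C(F)(F)F)c1` — 610 nM
compound 2 `O=C(CCSc1ccc2c(/C=C/c3ccccn3)n[nH]c2c1)Nc1ccc(Cl)c(C(F)(F)F)c1` — > 10000 nM
compound 3 `CN1CCN(Cc2ccc(NC(=O)CCSc3ccc4c(/C=C/c5ccccn5)n[nH]c4c3)cc2C(F)(F)F)CC1` — 2480 nM

All three compounds share the same core and differ only in the group carried on the aromatic ring of the amide side. In an ADME assay on BaF3 cells (Mus musculus) for antiproliferative activity, read by CCK-8 assay, with a stated time of 72 h (a lower number here means a stronger inhibitor of growth, a higher number a weaker inhibitor of growth), compound 1 gives 610 nM. Compound 2 sits at the limit of > 10000 nM in this assay, at which 1 of the 3 values shown sits, which is a limit of the assay and not a number. Compound 3 gives 2480 nM in this assay, the higher of the two numbers available; the gap to the nearest compound is a 4.1-fold higher number from compound 1 to compound 3 (0.61 log units; beyond the scatter). Against compound 2 the step is an at least 4.0-fold lower number from compound 2 to compound 3 (0.60 log units; beyond the scatter).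

Compound 4 `CC1CCN(Cc2ccc(NC(=O)CCSc3ccc4c(/C=C/c5ccccn5)n[nH]c4c3)cc2C(F)(F)F)CC1` is not yet measured. It differs from compound 3 by 4-methylpiperidin-1-yl in place of 4-methylpiperazin-1-yl on a saturated chain carbon bound to an aromatic carbon. Among the compounds with values here, none of the measured steps touches this change: each of them replaces the whole group on the aromatic carbon, whereas here only one ring atom of that group is exchanged, with the rest of the molecule untouched. Within the data shown here, with no directly comparable step, the expectation is a step of a 1.0-fold higher number from compound 3 to compound 4 (0.00 log units; within the scatter), in no particular direction and not beyond the scatter. Compound 4 is therefore expected to give about 2500 nM in this assay, with a range from 900 nM to 7000 nM.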

Compound 4, concentration for 50% growth inhibition: 4170 nM
Beside the measured number, compound 4's estimate is 1.7-fold (0.22 log units) below it, within the range that was stated.
By their numbers in this assay, from the lowest: compound 1; then compounds 3 and 4 (each within the scatter of the next). At a limit, above all of these: compound 2.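

The exchange of 4-methylpiperazin-1-yl for 4-methylpiperidin-1-yl replaces one ring nitrogen with a carbon and leaves the rest of the molecule untouched, and in this assay it gives a 1.7-fold higher number from compound 3 to compound 4 (0.23 log units; within the scatter), so this ring nitrogen makes no readable difference between these two compounds. The earlier steps shown here replaced a whole group at once, whereas this one shows that a change inside the group on the saturated chain carbon can leave the reading within the scatter, while the fluoro compound remains clearly apart, with a 6.8-fold higher number from compound 1 to compound 4 (0.83 log units; beyond the scatter). Compound 2 remains a limit and not a number, so its step gives only a bound, an at least 2.3-fold lower number from compound 2 to compound 4 (0.37 log units; beyond the scatter), and the one line of support concerns that limit: the limit of > 10000 nM in this assay, at which 1 of the 4 values shown sits.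

The compounds shown leave open whether morpholin-4-yl, with a ring oxygen in place of the nitrogen or carbon exchanged here, or piperidin-1-yl, without the methyl group, would also stay within the scatter of compound 3. They also leave open whether a small open-chain amine such as dimethylamino, carried on the same saturated chain carbon, would read like these ring amines.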